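Pentyl in place of hydrogen on selenium: compound 4

The compounds below may be only part of what the source reports. "The series", "measured", "known", "first", "only" and "open" are said of these compounds alone.

Going by the values given here, compound 2 `Nc1nc([SeH])nc2ncccc12` is the only member of the series with a number in an ADME assay on BEAS-2B cells (Homo sapiens) for cytotoxicity, read by MTT assay, with a stated time of 72 h; a lower number here means a stronger inhibitor of growth, a higher number a weaker inhibitor of growth: compound 2 gives 5890 nM. Compound 1 `[SeH]c1nc([SeH])c2ccccc2n1` carries no number in this assay: compound 1 gives "not determined" (no result reported). Compound 3 `[SeH]c1nc([SeH])c2cccnc2n1` likewise carries no number in this assay: compound 3 gives "not determined" (no result reported). Compound 2 therefore stands alone and cannot be ranked against them. Compound 4 `CCCCC[Se]c1nc(N)c2cccnc2n1` differs from compound 2 by pentyl in place of hydrogen on a selenium. Among the compounds with values here, no measured pair shows what such a change does in this assay, so the expectation rests on compound 2 alone. In this assay the expected step is a 1.5-fold lower number from compound 2 to compound 4 (0.17 log units; within the scatter), modest and, if anything, towards a lower number, though it may well sit within the usual scatter. Compound 4 is expected to give about 4000 nM in this assay, with a range from 1200 nM to 15000 nM.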

Compound 4, concentration for 50% growth inhibition: 16300 nM
Beside the measured number, compound 4's estimate is 4.1-fold (0.61 log units) below it; the whole stated range lies below it.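

In this assay, going by these compounds alone, pentyl in place of hydrogen on the selenium gives a 2.8-fold higher number from compound 2 to compound 4 (0.44 log units; beyond the scatter) and so provides the first measured step at this position. Here the change moves towards weaker growth inhibition, not stronger. No available evidence bears on the reason for this shift.

A single step leaves the trend with chain length open: a methyl or a longer chain such as octyl on the selenium could continue this direction or reverse it. Going by these compounds, whether a benzyl group or a chain ending in a carboxylic acid would behave like pentyl also remains open.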